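The source may hold more compounds than are shown below. What is called first, only, known or untested is meant among the compounds shown, and "the series" means these compounds.

Compound 1: `O=C(COc1ccc2c(=O)ccoc2c1)Nc1cccc(NC(=O)c2ccccc2)c1` gives 16 nM in an assay on isolated protein for inhibition of Rho-associated protein kinase 2 (Homo sapiens), read by scintillation counting, radiometric assay and 33P incorporation, with a stated time of 40 min, in the presence of a further agent that is not named here; a higher number here means a weaker inhibitor, a lower number a stronger inhibitor.
Compound 2: `CCCc1ccc(C(=O)Nc2cccc(NC(=O)COc3ccc4c(=O)ccoc4c3)c2)cc1` gives 14 nM in this assay.
Compound 3: `O=C(COc1ccc2c(=O)ccoc2c1)Nc1cccc(NC(=O)c2ccc(Br)cc2)c1` gives 49 nM in this assay.

Compound 3 stands highest of the three numbers in this assay. Its neighbours both sit beyond the scatter: the step from compound 1 to compound 3 reads a 3.1-fold higher number from compound 1 to compound 3 (0.49 log units; beyond the scatter), and the step from compound 2 to compound 3 reads a 3.5-fold higher number from compound 2 to compound 3 (0.54 log units; beyond the scatter). Compound 1 and compound 2 differ by only a 1.1-fold lower number from compound 1 to compound 2 (0.06 log units; within the scatter), so those two are not ordered against each other, but compound 3 is the weakest inhibitor among the three.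

Compound 4 is `N#Cc1ccc(C(=O)Nc2cccc(NC(=O)COc3ccc4c(=O)ccoc4c3)c2)cc1`. It differs from compound 3 in one place: cyano in place of bromo on an aromatic carbon. Going by the values given here, no measured step exchanges one substituent for another at this carbon apart from the bromo-for-propyl step, so the bearing of the data is indirect. The measured steps show that this carbon tolerates hydrogen or propyl well and that bromo costs a modest amount. Whether cyano behaves like bromo or like the other two cannot be read from these three compounds. The estimate therefore places compound 4 between the two, with a step of a 1.6-fold lower number from compound 3 to compound 4 (0.21 log units; within the scatter) expected that may still fall within the scatter.

Compound 4 is expected to give 30 nM in this assay, with a range from 10 nM to 90 nM.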

Compound 4, half-maximal inhibitory concentration: 15 nM
Compound 4: middle estimate off by 2.0-fold (0.30 log units), on the high side; the measured number falls inside the stated range.
By their numbers in this assay, from the lowest: compounds 2, 4 and 1 (each within the scatter of the next); then compound 3.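

In this assay the exchange of bromo for cyano reads a 3.3-fold lower number from compound 3 to compound 4 (0.51 log units; beyond the scatter) and so shows that the loss seen with bromo at this aromatic carbon does not extend to every group placed there. Cyano also stands level with the other two groups, with a 1.1-fold higher number from compound 2 to compound 4 (0.03 log units; within the scatter) for its exchange with propyl and a 1.1-fold lower number from compound 1 to compound 4 (0.03 log units; within the scatter) for its exchange with hydrogen, so among the four groups shown at this carbon only bromo sets its compound apart. No measurement is given that would explain this difference.

The compounds shown leave open how this carbon would respond to other groups, such as an amine, a carboxylic acid or a methoxy group, and whether chloro or iodo would read like bromo. They also leave open whether cyano in place of bromo would give a similar step at another carbon of this ring or on the other parts of the shared core.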